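Phenylsulfonyl in Place of Acetoxy on the Saturated Ring Carbon

A few compounds are considered here, and "the series" means these few. Any claim that something is new, unique, unknown or untested is made for them only; others in the source may bear on it.

Compound 1, `CO[C@H]1C(=O)N2C(C(=O)C(C)(C)C)=C(C)CS(=O)(=O)C12`: 106 h
Compound 2, `CO[C@H]1C(=O)N2C(C(=O)C(C)(C)C)=C(C)[C@@H](Sc3nnc(C)s3)S(=O)(=O)C12`: 27 h
Compound 3, `CO[C@H]1C(=O)N2C(C(=O)C(C)(C)C)=C(C)[C@@H](OC(C)=O)S(=O)(=O)C12`: 6.3 h

These three compounds were measured in a physicochemical assay, at pH 7.4; a higher number here means that the compound lasts longer, a lower number that the compound disappears faster. Compound 3 stands at the bottom of the three numbers: its nearest neighbour is compound 2, the step of a 4.3-fold lower number from compound 2 to compound 3 (0.63 log units; beyond the scatter), and its furthest is compound 1, the step of a 17-fold lower number from compound 1 to compound 3 (1.23 log units; beyond the scatter). Both steps lie beyond the scatter, so compound 3 is clearly the shortest-lived of the set.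

Compound 4, `CO[C@H]1C(=O)N2C(C(=O)C(C)(C)C)=C(C)[C@@H](S(=O)(=O)c3ccccc3)S(=O)(=O)C12`, has not yet been measured. The change from compound 3 is phenylsulfonyl in place of acetoxy on a saturated ring carbon.

Going by the values given here, two measured steps bear on this saturated ring carbon. Replacing hydrogen there by a (5-methyl-1,3,4-thiadiazol-2-yl)sulfanyl group gave a 3.9-fold lower number from compound 1 to compound 2 (0.59 log units; beyond the scatter), and replacing it by acetoxy gave a 17-fold lower number from compound 1 to compound 3 (1.23 log units; beyond the scatter). Every substituent put at this carbon so far has lowered the number, with the size depending on the group. Phenylsulfonyl, being a third kind of group, has no direct precedent here, so the step from compound 3 is expected to be small and uncertain in direction, a 1.3-fold higher number from compound 3 to compound 4 (0.10 log units; within the scatter).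

Compound 4 is therefore estimated to give 8 h in this assay, within a range from 2.5 h to 25 h.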

Compound 4, half-life: 10 h
For compound 4 the middle estimate is 1.3-fold (0.10 log units) below the measured one; measured number inside the range.
By their numbers in this assay, from the lowest: compounds 3 and 4 (each within the scatter of the next); then compound 2; then compound 1.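

Phenylsulfonyl on this saturated ring carbon, next to the ring sulfur, also falls well short of hydrogen in this assay, with an 11-fold lower number from compound 1 to compound 4 (1.03 log units; beyond the scatter), so all three groups placed here so far lower the number, and none of the compounds shown goes against this. The larger phenylsulfonyl group, with its six-membered aromatic ring, cannot be told apart from the smaller acetoxy group in this assay, since the change gives a 1.6-fold higher number from compound 3 to compound 4 (0.20 log units; within the scatter), yet it remains separable from the sulfur-linked heteroaromatic group, with a 2.7-fold lower number from compound 2 to compound 4 (0.43 log units; beyond the scatter) as the step between those two. Nothing available explains why these groups differ or why the last two cannot be separated.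

The compounds shown leave open how an amine, a carboxylic acid or a plain methyl group at this carbon would compare with hydrogen and whether any such group would leave the number unchanged. From the compounds shown here alone, all four compounds also keep the methoxy group and the (tert-butyl)carbonyl group, so it remains unknown whether the same ranking would hold if a longer chain replaced either one.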